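Removing a methyl from an inactive aminopyrazole

A few compounds are considered here, and "the series" means these few. Any claim that something is new, unique, unknown or untested is made for them only; others in the source may bear on it.

Measured compounds:
compound 1 `Cc1[nH]nc(N)c1-c1ccc(Cl)c(Cl)c1`, > 100000 nM
compound 2 `Cc1ccc(-c2c(N)n[nH]c2C)cc1C`, > 100000 nM
compound 3 `Cc1[nH]nc(N)c1-c1ccc2ccccc2c1`, > 100000 nM

In an assay on Sf9 cells for inhibition of mitogen-activated protein kinase kinase kinase 14 (Homo sapiens), read by ADP-Glo, with a stated time of 60 min (a lower number here means a stronger inhibitor, a higher number a weaker inhibitor), compound 1 gives only a limit, > 100000 nM. In this assay compound 3 likewise gives only a limit, > 100000 nM. Among the measured compounds shown here, compound 2 stands at the same place: in this assay compound 2 gives only a limit, > 100000 nM, so no number is known for it, and no step between any two of the measured compounds can be sized. What the series shows is the limit of > 100000 nM in this assay, at which 3 of the 3 values shown sit.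

Compound 4 `Cc1cccc(-c2c(N)n[nH]c2C)c1` differs from compound 2 by hydrogen in place of methyl on an aromatic carbon. With every measured value sitting at the limit, no direction can be read from the numbers. The expectation is that compound 4 stays at the limit in this assay, with the expected step from compound 2 to compound 4 being a step that the limit leaves unreadable from compound 2 to compound 4, none beyond the scatter. The estimate for compound 4 in this assay is therefore 150000 nM, within 50000 nM to 500000 nM, most likely reported again only as a limit.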

Compound 4, half-maximal inhibitory concentration: > 100000 nM
Compound 4: no number, only a limit; the forecaster's own chance of this, stated with the estimate: 85%; the middle value lies beyond the limit too.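

In this assay compound 4 gives only a limit, > 100000 nM. Among the compounds shown here, compound 2 also stands at a limit, so no step from compound 2 to compound 4 can be read. The compounds shown leave open whether any change on the shared core would give a measurable value: the limit of > 100000 nM in this assay, at which 4 of the 4 values shown sit.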